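The source may report more compounds than this note shows. Statements on the series, on what has been measured and on what is new or still open speak of the compounds shown alone.

Measured so far in a functional assay on cells (Melanoma cell, Homo sapiens) for inhibition; on this read-out higher numbers stand for weaker inhibition of growth and lower numbers for stronger inhibition of growth:
- compound 1, `N=C(N)N/N=C/c1c(-c2cccs2)nc2sccn12`: 15100 nM
- compound 2, `CCOC(=O)c1nc2sc(Cl)cn2c1/C=N\NC(=N)N`: 19500 nM
- compound 3, `Cc1cn2c(/C=N/NC(=N)N)c(-c3cccs3)nc2s1`: 2240 nM

Among these three, compound 1 holds the second highest number. Its nearest neighbour is compound 2, whose value lies within the usual scatter of that of compound 1, so the two cannot be told apart. Compound 3 is the one furthest from it: a 6.7-fold lower number from compound 1 to compound 3 (0.83 log units; beyond the scatter), a modest step obtained by placing a methyl on an aromatic carbon of the shared core.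

Compound 4, `Cc1cc(-c2nc3sccn3c2/C=N/NC(=N)N)c(C)s1`, differs from compound 1 in another place: 2,5-dimethylthiophen-3-yl in place of thiophen-2-yl on an aromatic carbon. Within the data shown here, no measured pair changes this part of the structure, so the only step known, from compound 1 to compound 3, concerns a different position and bears on this change only in showing that added methyl groups elsewhere on the core gave a lower number. A small shift toward a lower number is therefore expected, well within a modest range, for compound 4: a 1.9-fold lower number from compound 1 to compound 4 (0.28 log units; within the scatter). The estimate for compound 4 in this assay is 8000 nM, expected to fall between 2500 nM and 30000 nM.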

Compound 4, concentration for 50% growth inhibition: 16200 nM
The estimate for compound 4 lay 2.0-fold (0.31 log units) below the measured number, within the range that was stated.
By their numbers in this assay, from the lowest: compound 3; then compounds 1, 4 and 2 (each within the scatter of the next).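

In this assay, among these compounds, the replacement of thiophen-2-yl by 2,5-dimethylthiophen-3-yl gives the first step at this position, a 1.1-fold higher number from compound 1 to compound 4 (0.03 log units; within the scatter), and on this read-out compound 1 and compound 4 cannot be told apart. The position, on an aromatic carbon next to the ring nitrogen, therefore accepts this group with its added methyl groups without a difference beyond the scatter, unlike the methyl step on the shared core, a 6.7-fold lower number from compound 1 to compound 3 (0.83 log units; beyond the scatter). No measurement shown here offers an explanation for this result.

The compounds shown do not separate the effect of the two methyl groups from that of moving the attachment from thiophen-2-yl to thiophen-3-yl. They also leave open how this position would respond to a ring without sulfur, such as phenyl, or to an amine.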